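Benzyl to Isobutyl on a Weakly Inhibiting Core

The source may report more compounds than this note shows. Statements on the series, on what has been measured and on what is new or still open speak of the compounds shown alone.

Compound 1 `C/C(=N\Cc1ccccc1)c1c(O)c2ccccc2[nH]c1=O` was tested in an assay on isolated protein for inhibition of myosin-2 (Bos taurus), read by spectrophotometry, with a stated time of 24 min (on this read-out higher numbers stand for weaker inhibition and lower numbers for stronger inhibition), where compound 1 gives only a limit of the assay, >= 100000 nM. Compound 2 `C/C(=N\Nc1ccccc1)c1c(O)c2ccccc2oc1=O` in this assay gives 27000 nM. Compound 3 `C/C(=N\Cc1ccccc1C)c1c(O)c2ccccc2oc1=O` in this assay likewise reaches only a limit, >= 100000 nM. Compound 1 thus stands at the limit of >= 100000 nM in this assay, at which 2 of the 3 values shown sit. Compound 4 `C/C(=N\CC(C)C)c1c(O)c2ccccc2[nH]c1=O` carries isopropyl in place of phenyl on a saturated chain carbon bound to a double-bonded nitrogen; cut one bond further out, the change reads benzyl to isobutyl. For the measured compounds named here, no step between measured compounds has been recorded, so the effect of this change is unknown from the data. The step is expected to be a number no higher from compound 1 to compound 4 (the limit leaves the size open), none beyond the scatter. Compound 4 is therefore expected to give 100000 nM, between 30000 nM and 300000 nM, most probably again reported only as a limit.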

Compound 4, half-maximal inhibitory concentration: >= 100000 nM
Compound 4 was reported as a limit; the forecaster's own chance of this, stated with the estimate: 80%; the middle value sits exactly at the limit.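

For the compounds shown here, compound 1 and compound 4 both give only a limit in this assay, so no step between them can be read. The compounds shown leave open whether benzyl and isobutyl on the shared core differ in inhibition at all.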